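Trimming an Ethyl Ether Down to a Free Hydroxyl

A few compounds are considered here, and "the series" means these few. Any claim that something is new, unique, unknown or untested is made for them only; others in the source may bear on it.

Three compounds built on one shared core were tested in an assay on HEK293 cells for antagonist activity at Neuronal acetylcholine receptor; alpha3/beta4 (Rattus norvegicus), read by FLIPR, using a membrane potential dye; on this read-out lower numbers stand for stronger inhibition and higher numbers for weaker inhibition. Compound 1 `COCCO[C@H]1CC[C@H]2CCN(C)[C@H]2C1` has a fully saturated core and a methoxyethyl ether. In this assay compound 1 gives > 300000 nM, which is a limit of the assay rather than a number. Compound 2 `CCO[C@H]1CC=C2CCN(C)[C@H]2C1` has a double bond in its core and an ethyl ether. In this assay compound 2 gives > 300000 nM, again only a limit. Compound 3 `CN1CCC2=CC[C@H](OCc3ccccc3)C[C@@H]21` keeps that core and lengthens the ether. In this assay compound 3 gives > 300000 nM, once more a limit. Among the measured compounds shown here, all three values sit together at the limit of > 300000 nM in this assay, at which 3 of the 3 values shown sit, so the one step among measured compounds, a step that the two limits leave unreadable from compound 2 to compound 3, cannot be read in size or direction. Compound 2 therefore stands at the limit, with nothing above or below it to set a scale.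

Compound 4 `CN1CCC2=CC[C@H](O)C[C@@H]21` is the untested partner of compound 2. The change is hydrogen in place of ethyl on an oxygen on a saturated carbon. For the measured compounds named here, the only measured step that touches this position is the unreadable one from compound 2 to compound 3, so no size or direction can be taken from it. With every neighbour at the limit, compound 4 is expected to land there too. For compound 4 the estimate is 300000 nM, with a range from 100000 nM to 1000000 nM. The step this estimate implies is expected to be a number no higher from compound 2 to compound 4 (the limit leaves the size open), nothing beyond the scatter.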

Compound 4, half-maximal inhibitory concentration: > 300000 nM
Compound 4: only a limit was reported; the forecaster's own chance of this, stated with the estimate: 85%; the middle value lies on the limit itself.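

Neither compound 2 nor compound 4 gives a number, so the change from ethoxy to hydroxy yields no readable step, and both results are only limits of the assay: (the limit of > 300000 nM in this assay, at which 4 of the 4 values shown sit). The compounds shown leave open how strongly any of them inhibits in this assay and whether changing the ether matters at all.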